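A few compounds are considered here, and "the series" means these few. Any claim that something is new, unique, unknown or untested is made for them only; others in the source may bear on it.

Measured so far in a functional assay on SW480 cells (Homo sapiens) for antiproliferative activity, read by MTT assay, with a stated time of 48 h; on this read-out lower numbers stand for stronger inhibition and higher numbers for weaker inhibition:
- compound 1 `CCCCCCCCCC(CCO)n1cnc2c(Cl)ncnc21` gives 1150 nM
- compound 2 `CCCCCCCCCC(CCOS(C)(=O)=O)n1cnc2c(Cl)ncnc21` gives 5390 nM
- compound 3 `CCCCCCCCCC(CCn1cc(-c2ccccc2)nn1)n1cnc2c(Cl)ncnc21` gives 9920 nM

Compound 2 sits in the upper pair of these numbers (a 1.8-fold higher number from compound 2 to compound 3 (0.26 log units; within the scatter)), clearly off the number of compound 1. Going on to compound 4 `C=C(CO)C(CCCCCCCCC)n1cnc2c(Cl)ncnc21` means 1-(hydroxymethyl)ethenyl in place of 2-((methylsulfonyl)oxy)ethyl on a saturated chain carbon bound to an aromatic nitrogen and a saturated chain carbon (counted: 1-(hydroxymethyl)ethenyl in place of 2-((methylsulfonyl)oxy)ethyl on a saturated chain carbon bound to an aromatic nitrogen and a saturated chain carbon).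

A hydroxy returns with this change. Two modest steps away from the hydroxy of compound 1 bear on it: a 4.7-fold higher number from compound 1 to compound 2 (0.67 log units; beyond the scatter) and an 8.6-fold higher number from compound 1 to compound 3 (0.94 log units; beyond the scatter) both went upward. Among the measured compounds shown here, no measured compound carries the ethenyl, so the first of these steps may not reverse in full. A lower number is expected in this assay, of modest size and somewhat short of that step. The expected step is a 2.7-fold lower number from compound 2 to compound 4 (0.43 log units; beyond the scatter). For compound 4 the estimate is 2000 nM, with an expected range from 700 nM to 6000 nM.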

Compound 4, half-maximal inhibitory concentration: 27600 nM
Compound 4: the middle estimate sits 14-fold (1.14 log units) below what was measured, outside the stated range (above it).
By their numbers in this assay, from the lowest: compound 1; then compounds 2 and 3 (each within the scatter of the next); then compound 4.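

Keeping a hydroxy does not keep the activity at this saturated chain carbon: in this assay, 1-(hydroxymethyl)ethenyl in place of 2-hydroxyethyl gives the only large step in the series (a 24-fold higher number from compound 1 to compound 4 (1.38 log units; beyond the scatter)). The same group also stands off the 2-((methylsulfonyl)oxy)ethyl group, which has no hydrogen-bond donor (a 5.1-fold higher number from compound 2 to compound 4 (0.71 log units; beyond the scatter)), so among these compounds a hydrogen-bond donor on this substituent does not by itself set the order, with compound 1 and compound 4 both carrying one at opposite ends of the numbers. No measurement available here accounts for the loss.

The compounds shown do not separate the ethenyl from the change in how the hydroxy is attached. From the compounds shown here alone, a 1-(hydroxymethyl)ethyl group or a 1-methylethenyl group at this carbon would address that, while an amine or a carboxylic acid in place of the hydroxy of compound 1 remains open.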